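The source may report more compounds than this note shows. Statements on the series, on what has been measured and on what is new or still open speak of the compounds shown alone.

Measured so far in a functional assay on HL-60 cells (Homo sapiens) for antiproliferative activity, read by CCK-8 assay, with a stated time of 72 h; a higher number here means a weaker inhibitor, a lower number a stronger inhibitor:
compound 1 `Cc1cc(Nc2cc(N3CCN(C)CC3)nc(Nc3ccc(C#N)cc3)n2)n[nH]1` gives 21.8 nM;
compound 2 `COc1ccc(Nc2nc(Nc3cc(C)[nH]n3)cc(N3CCN(C)CC3)n2)cc1` gives 335 nM;
compound 3 `COc1cccc(Nc2nc(Nc3cc(C)[nH]n3)cc(N3CCN(C)CC3)n2)c1` gives 397 nM.

Compound 3 carries the highest number of the three. Compound 2 sits closest to it, and a 1.2-fold higher number from compound 2 to compound 3 (0.07 log units; within the scatter) lies within the scatter, so the two cannot be ordered. Compound 1 stands far off: an 18-fold higher number from compound 1 to compound 3 (1.26 log units; beyond the scatter), a large step, and a 15-fold higher number from compound 1 to compound 2 (1.19 log units; beyond the scatter) in the same direction.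

Compound 4 `Cc1cc(Nc2cc(N3CCN(C)CC3)nc(Nc3ccc([N+](=O)[O-])cc3)n2)n[nH]1` differs from compound 3 in one place: 4-nitrophenyl in place of 3-methoxyphenyl on a nitrogen on an aromatic ring. For the measured compounds named here, no measured step swaps the 3-methoxyphenyl directly for a 4-nitrophenyl. Going by the values given here, the steps that bear on it are those that exchange the aryl group at the same nitrogen: from compound 1 to compound 3 and from compound 1 to compound 2, both large and both moving from a 4-cyanophenyl to a methoxyphenyl with a much higher number. Compound 4 brings in a 4-nitrophenyl, a group not yet measured here, so the expectation is set between compound 1 and compound 3.

Compound 4 is therefore expected to give a lower number than compound 3, with a 6.6-fold lower number from compound 3 to compound 4 (0.82 log units; beyond the scatter) as the estimated step, and the estimate for compound 4 in this assay is 60 nM, ranging from 15 nM to 250 nM.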

Compound 4, half-maximal inhibitory concentration: 69.8 nM
For compound 4 the middle estimate is 1.2-fold (0.07 log units) below the measured one, within the range that was stated.
By their numbers in this assay, from the lowest: compound 1; then compound 4; then compounds 2 and 3 (each within the scatter of the next).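

In this assay the 4-nitrophenyl on this nitrogen gives a clearly lower number than either methoxyphenyl (a 5.7-fold lower number from compound 3 to compound 4 (0.75 log units; beyond the scatter); a 4.8-fold lower number from compound 2 to compound 4 (0.68 log units; beyond the scatter)), so among the four compounds a low number is not unique to the 4-cyanophenyl of compound 1. The two groups in that lower range are still not interchangeable, since exchanging cyano for nitro on the same aromatic carbon carries its own step beyond the scatter (a 3.2-fold higher number from compound 1 to compound 4 (0.51 log units; beyond the scatter)), and the aryl groups now fall into three levels, with compound 1 lowest, compound 4 next, and compounds 2 and 3 together at the top. No measurement shown here offers an explanation for this ordering.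

The compounds shown leave open where an unsubstituted phenyl, a 4-aminophenyl or a 4-carboxyphenyl on this nitrogen would fall relative to these three levels. They also leave open whether a 3-nitrophenyl or a 3-cyanophenyl would match its 4-substituted counterpart, as the two methoxyphenyl compounds, which lie within the scatter of each other, might suggest.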